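The source may report more compounds than this note shows. Statements on the series, on what has been measured and on what is new or still open speak of the compounds shown alone.

Measured so far:
compound 1 `COc1ccccc1NC(=O)CCc1nc(Cc2ccc(NC(C)=O)cc2)no1` gives 87.7% in a functional assay on the whole organism (strain C57BL/6) for inhibition, with Mus musculus as the target, read by paw edema, with stated times of 1 h and 4 h, at a dose of 100 mg/kg by the oral route; a higher number here means more inhibition at the dose given (going by the name of the read-out), a lower number less inhibition
compound 2 `CC(=O)Nc1ccc(Cc2noc(CCC(=O)Nc3ccccc3F)n2)cc1` gives 67.1%

Among the measured compounds shown here, of these two, compound 2 stands lowest in this assay, with compound 1 as the only other number: a number 20.6 percentage points lower from compound 1 to compound 2 (beyond the scatter). Compound 3 `CC(=O)Nc1ccc(Cc2noc(CCC(=O)Nc3ccc(F)cc3F)n2)cc1` differs from compound 2 by fluoro in place of hydrogen on an aromatic carbon. For the measured compounds named here, the single measured step concerns a different group, so no step bears directly on this change; it shows only that one substituent swap on this ring moved the read-out by a modest amount. For compound 3 a step of a number 3.1 percentage points lower from compound 2 to compound 3 (within the scatter) is expected, not beyond the scatter. The estimate for compound 3 is 64%, between 45% and 82%.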

Compound 3, a percentage reported as inhibition, in the whole organism at one dose (the size of the read-out at that dose, not a potency): 52.1%
Compound 3: middle estimate off by 11.9 percentage points, on the high side; the measured number falls inside the stated range.
By their numbers in this assay, from the lowest: compound 3; then compound 2; then compound 1.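

In this assay, among the compounds shown here, fluoro in place of hydrogen at this place, para to a large group and meta to a fluoro group, is not neutral: a number 15 percentage points lower from compound 2 to compound 3 (beyond the scatter) is a drop the earlier compounds could not show, since their one step concerned a different group. The change from 2-methoxyphenyl to 2,4-difluorophenyl gives a number 35.6 percentage points lower from compound 1 to compound 3 (beyond the scatter) and so adds up to a large loss. Nothing measured here explains the drop.

Going by these compounds, it remains open whether an amine, a methoxy group or a carboxylic acid at this place would lower the read-out as fluoro does.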